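From hydroxy to methylamino on a propyl chain

The source may report more compounds than this note shows. Statements on the series, on what has been measured and on what is new or still open speak of the compounds shown alone.

In a functional assay on NCI-H460 cells (Homo sapiens) for antiproliferative activity (on this read-out lower numbers stand for stronger inhibition and higher numbers for weaker inhibition), the measured compounds stand as follows
- compound 1 `Cn1cc(C2=C(c3c[nH]c4cc(Br)ccc34)C(=O)NC2=O)c2ccccc21` gives 970 nM
- compound 2 `O=C1NC(=O)C(c2cn(CCCO)c3ccccc23)=C1c1c[nH]c2ccccc12` gives > 10000 nM (a limit of the assay)

Compound 2 has no number on this read-out and sits at the limit of > 10000 nM in this assay, at which 1 of the 2 values shown sits (a limit, not a measured value). Compound 1 alone has a number, at 970 nM on the same read-out.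

Compound 3 `CNCCCn1cc(C2=C(c3c[nH]c4ccccc34)C(=O)NC2=O)c2ccccc21` is compound 2 with methylamino in place of hydroxy on a saturated chain carbon, three bonds along the chain from an aromatic nitrogen, so that 3-hydroxypropyl becomes 3-(methylamino)propyl. Going by the values given here, no measured pair here shows what such an exchange does, so the expectation is loose. Some gain in inhibition is expected rather than none, as compound 1 at 970 nM shows that a related structure can reach a measurable value. The expected change is an at least 4.0-fold lower number from compound 2 to compound 3 (0.60 log units; beyond the scatter) toward stronger inhibition, and another result at the limit remains possible. Compound 3 is estimated at 2500 nM (expected range 400 nM to 10000 nM).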

Compound 3, half-maximal inhibitory concentration: > 10000 nM
Compound 3 was reported as a limit (the forecaster's own chance of this, stated with the estimate: 25%); middle value at least 4.0-fold (0.60 log units) away from the limit.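

In this assay compound 3 gives > 10000 nM, a limit of the assay and not a number. Compound 2 also stands at a limit, so no step can be read from compound 2 to compound 3: the limit of > 10000 nM in this assay, at which 2 of the 3 values shown sit. The compounds shown leave open how 3-hydroxypropyl and 3-(methylamino)propyl actually compare on this read-out.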